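Urea in Place of Amide: Expected Effect on Compound 4

This account rests on a few compounds, and the source may have more. Where it says the series, first, only, none or still open, it means among the compounds named here.

Measured compounds:
compound 1, `O=C(Nc1cccc(-n2cc(-c3ccncc3)c(-c3ccc(Cl)c(O)c3)n2)c1)Nc1cccc(C(F)(F)F)c1`, 1060 nM
compound 2, `COc1cc(-c2nn(-c3cccc(NC(=O)Nc4cc(C(F)(F)F)cc(C(F)(F)F)c4)c3)cc2-c2ccncc2)ccc1Cl`, 410 nM
compound 3, `COc1cc(-c2nn(-c3cccc(NC(=O)c4cccc(C(F)(F)F)c4)c3)cc2-c2ccncc2)ccc1Cl`, 1200 nM

In a functional assay on OVCAR-3 cells (Homo sapiens) for inhibition, read by sulforhodamine B assay, with a stated time of 48 h (a lower number here means a stronger inhibitor, a higher number a weaker inhibitor), compound 3 gives 1200 nM, the highest of the three numbers. Compound 1 gives 1060 nM, which lies within the scatter of compound 3, so the two cannot be told apart. Compound 2 gives 410 nM, a number beyond the scatter below compound 3; compound 2 differs from compound 3 in more than one place, so no single cause for this gap can be named.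

Compound 4, `COc1cc(-c2nn(-c3cccc(NC(=O)Nc4ccc(Cl)c(Cl)c4)c3)cc2-c2ccncc2)ccc1Cl`, has not yet been measured in this assay. It differs from compound 3 in one place: (3,4-dichlorophenyl)amino in place of 3-(trifluoromethyl)phenyl on a carbonyl carbon. In other words the amide of compound 3 becomes a urea in compound 4, the arrangement found in compound 1 and compound 2. Since both ureas here give numbers at or below that of compound 3, the estimate for compound 4 is a modest step toward a lower number, a 2.0-fold lower number from compound 3 to compound 4 (0.30 log units; within the scatter), though it may still fall within the scatter. The expected value for compound 4 is 600 nM, with a range from 250 nM to 1500 nM.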

Compound 4, half-maximal inhibitory concentration: 700 nM
Beside the measured number, compound 4's estimate is 1.2-fold (0.07 log units) below it, within the range that was stated.
By their numbers in this assay, from the lowest: compounds 2, 4, 1 and 3 (each within the scatter of the next, the first and the last beyond it).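

Among the compounds shown here, replacing 3-(trifluoromethyl)phenyl with (3,4-dichlorophenyl)amino on the carbonyl carbon turns the amide into a urea, and this is the first change in this assay that can be read in one place (a 1.7-fold lower number from compound 3 to compound 4 (0.23 log units; within the scatter)). Compound 3 and compound 4 therefore cannot be told apart, so this position accepts the urea with its dichlorinated ring, and no clear gain in potency is shown. No measurement shown here explains this result.

From the compounds shown here alone, this single step changes both the link and the ring's substituents, so their separate contributions remain unknown. Going by these compounds, it also remains open whether a sulfonamide or thiourea link at this position, or a methoxy group on the ring in place of a chlorine, would move the number beyond the usual scatter.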